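Replacing the Dimethoxyphenoxy Group in a Bcl-2 Sulfonamide Series

A few compounds are considered here, and "the series" means these few. Any claim that something is new, unique, unknown or untested is made for them only; others in the source may bear on it.

Compound 1: `COc1ccc(Oc2ccccc2-c2ccsc2S(=O)(=O)N2CCN(C(=O)Nc3cccc([N+](=O)[O-])c3)CC2)cc1OC`, 18%
Compound 2: `COc1ccc(Oc2ccccc2-c2ccsc2S(=O)(=O)N2CCN(C(=O)Nc3ccc(F)cc3)CC2)cc1OC`, 15%
Compound 3: `COc1ccc(Oc2ccccc2-c2ccsc2S(=O)(=O)N2CCN(C(=S)Nc3ccc(Cl)cc3)CC2)cc1OC`, 18%

Of the compounds shown here, three share a core and have been tested in an assay for binding affinity to Apoptosis regulator Bcl-2 (Homo sapiens), read by fluorescence polarization, with stated times of 30 min and 20 min, tested at 100 uM; on this read-out lower numbers stand for less inhibition and higher numbers for more inhibition at the one concentration tested (going by the name of the read-out). Compound 1 gives 18%, compound 2 gives 15%, and compound 3 gives 18%. Compound 3 stands level with compound 1 at the digits printed, the two together the highest of the three numbers, while the step of a number 3 percentage points higher from compound 2 to compound 3 (within the scatter) also lies within the scatter. All three values sit close together.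

Compound 4 is `O=S(=O)(c1sccc1-c1ccccc1Oc1ccc(O)c(O)c1)N1CCN(C(=S)Nc2ccc(Cl)cc2)CC1`. The change from compound 3 reads (3,4-dihydroxyphenyl in place of 3,4-dimethoxyphenyl on an oxygen on an aromatic ring). Among the compounds with values here, none of the measured steps touches this part of the molecule: a number 3 percentage points lower from compound 1 to compound 2 (within the scatter) and no change at the digits printed from compound 1 to compound 3 (within the scatter) concern only the group on the amine nitrogen in the ring, and both stay within the scatter. Within the data shown here, there is thus no measured step that bears on the change to compound 4, and a step of no more than the scatter is expected in this assay, with the direction open. For compound 4 the estimate is 18%, in the range 5% to 35%, meaning an expected step of no change at the digits printed from compound 3 to compound 4 (within the scatter).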

Compound 4, a percentage reported as inhibition, at one concentration (the size of the read-out at that concentration, not a potency): 2%
Beside the measured number, compound 4's estimate is 16 percentage points above it, outside the stated range (below it).
By their numbers in this assay, from the lowest: compound 4; then compounds 2, 1 and 3 (each within the scatter of the next).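

In this assay, within the data shown here, the change to 3,4-dihydroxyphenyl on this oxygen gives a number 16 percentage points lower from compound 3 to compound 4 (beyond the scatter) and is the only step in the set beyond the scatter, while the steps at the group on the amine nitrogen in the ring all stayed within it. The position carrying the 3,4-dimethoxyphenoxy group therefore responds to a replacement, and the entering group carries hydrogen-bond donors that the leaving group lacks, though the compounds cannot say whether that difference is what counts. Nothing measured here accounts for the step.

Going by these compounds, whether an unsubstituted phenyl, a 3,4-difluorophenyl or a phenyl with a single methoxy group would stay level with compound 3 or drop like compound 4 remains open. So does whether the same replacement would give a similar step in compound 1 or compound 2.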